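A few compounds are considered here, and "the series" means these few. Any claim that something is new, unique, unknown or untested is made for them only; others in the source may bear on it.

Working notes on the series. In a functional assay on HEK293 cells (Homo sapiens) for cytotoxicity (a lower number here means that less compound is tolerated, a higher number that more compound is tolerated), compound 1 (`COc1ccc([C@H]2CC(=O)N(c3cccc(C#N)c3)C2)cc1OC1CCCC1`) gives > 10000 nM, which is a limit of the assay and not a number. Compound 2 (`COc1ccc([C@H]2CC(=O)N(c3ccc(S(C)(=O)=O)cc3)C2)cc1OC1CCCC1`) gives > 10000 nM, which is also a limit. The measured record therefore consists only of the limit of > 10000 nM in this assay, at which 2 of the 2 values shown sit.

Compound 3 (`COc1ccc([C@H]2CC(=O)N(c3cccc(NCCCc4ccccc4)c3)C2)cc1OC1CCCC1`) carries (3-phenylpropyl)amino in place of cyano on an aromatic carbon of compound 1: (3-phenylpropyl)amino in place of cyano on an aromatic carbon. For the measured compounds named here, the only measured step is a step that the two limits leave unreadable from compound 1 to compound 2, with 4-(methylsulfonyl)phenyl in place of 3-cyanophenyl on an amide-type nitrogen in a ring. Going by the values given here, it touches the same substituted ring but has no readable size, and no measured compound carries the entering group. Nothing measured therefore points to a shift in either direction, although the untested group leaves some room for a lower reading in this assay.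

The expected outcome is a step that the limit leaves unreadable from compound 1 to compound 3, with no step beyond the scatter anticipated and another limit the likeliest report. For compound 3 the estimated value is 20000 nM, within an expected range of 6000 nM to 60000 nM.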

Compound 3, half-maximal cytotoxic concentration: > 10000 nM
Compound 3 gave a limit, no number; the forecaster's own chance of this, stated with the estimate: 70%; the middle value does not contradict the limit.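

Compound 3 also gives a limit and not a number in this assay, so no step can be read between compound 1 and compound 3. All the values shown sit at one limit: the limit of > 10000 nM in this assay, at which 3 of the 3 values shown sit.

The compounds shown leave open whether either change on the shared core alters the half-maximal cytotoxic concentration at all, as none of them gives a number.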